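The source may hold more compounds than are shown below. What is called first, only, known or untested is meant among the compounds shown, and "the series" means these compounds.

Compound 1 `CNC(=O)c1cnc(NC(=O)NC2CCCCC2)n2nc(-c3ccco3)nc12` — in an assay on CHO cells for displacement of a labelled ligand from adenosine receptor A1 (Homo sapiens) (on this read-out lower numbers stand for stronger inhibition and higher numbers for weaker inhibition), compound 1 gives 8990 nM.
Compound 2 `O=C(Nc1ncc(C(=O)O)c2nc(-c3ccco3)nn12)NC1CCCCC1` — compound 2 gives only > 100000 nM, which is a limit of the assay and not a number.
Compound 3 `CCOC(=O)c1cnc(N2CCCCC2)n2nc(-c3ccco3)nc12` — compound 3 gives 8860 nM.

As far as these compounds go, compound 2 therefore stands at the weak end of the three, at the limit (the limit of > 100000 nM in this assay, at which 1 of the 3 values shown sits), and its true value is unknown beyond that. Among the compounds with values here, the only measured step that reaches it is an at least 11-fold higher number from compound 1 to compound 2 (1.04 log units; beyond the scatter), the change from a methylamide to a free carboxylic acid on the shared core, which went beyond the scatter. Compound 3, which carries an ethyl ester and a piperidine instead of the acid and the urea, sits at a value close to that of compound 1.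

Compound 4 `O=C(O)c1cnc(NCc2ccc(F)cc2)n2nc(-c3ccco3)nc12` keeps the carboxylic acid of compound 2 and differs from it in one place: 4-fluorobenzyl in place of cyclohexylcarbamoyl on a nitrogen on an aromatic ring. Within the data shown here, no measured step tests this change. Because the acid that drove an at least 11-fold higher number from compound 1 to compound 2 (1.04 log units; beyond the scatter) remains in place, compound 4 is expected to stay weak in this assay, and the step of an at least 1.6-fold lower number from compound 2 to compound 4 (0.22 log units; that floor lies within the scatter) is expected to be small, possibly not beyond the scatter, with a real chance that only a limit is again reported. Compound 4 is estimated at 60000 nM, between 10000 nM and 300000 nM.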

Compound 4, inhibition constant: > 100000 nM
Compound 4: only a limit was reported; the forecaster's own chance of this, stated with the estimate: 50%; at least 1.6-fold (0.22 log units) between middle value and limit.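

In this assay compound 4 gives > 100000 nM, which is a limit of the assay and not a number. Compound 2 sits at the same limit, and the step between compound 2 and compound 4 cannot be read: the limit of > 100000 nM in this assay, at which 2 of the 4 values shown sit.

The compounds shown leave open where the true values of compound 2 and compound 4 lie, and whether 4-fluorobenzyl in place of cyclohexylcarbamoyl changes the read-out at all.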